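The source may report more compounds than this note shows. Statements on the series, on what has been measured and on what is new or still open speak of the compounds shown alone.

Compound 1 `COc1ccc(S(=O)(=O)N(CC(N)=O)c2ccc(N(CC(N)=O)S(=O)(=O)c3ccc(NC(C)=O)cc3)c3ccccc23)cc1` carries an acetamido group on the shared core. In a functional assay on cells (Peritoneal macrophage, Mus musculus) for cytotoxicity, with a stated time of 24 h (on this read-out higher numbers stand for lower toxicity in this test and lower numbers for higher toxicity in this test), compound 1 gives > 50000 nM, which is a limit of the test and not a number. Compound 2 `CCCCC(=O)Nc1ccc(S(=O)(=O)N(CC(N)=O)c2ccc(N(CC(N)=O)S(=O)(=O)c3ccc(OC)cc3)c3ccccc23)cc1` and compound 3 `COc1ccc(S(=O)(=O)N(CC(N)=O)c2ccc(N(CC(N)=O)S(=O)(=O)c3ccc(NC(=O)CCN4CCCCC4)cc3)c3ccccc23)cc1` are its measured neighbours. In this assay compound 2 gives > 100000 nM, again a limit. In this assay compound 3 gives > 100000 nM, also a limit. The step that the two limits leave unreadable from compound 1 to compound 2 and the step that the two limits leave unreadable from compound 1 to compound 3 therefore cannot be sized, and the same holds for a step that the two limits leave unreadable from compound 2 to compound 3. All the three values show is that the limit of > 100000 nM in this assay, at which 2 of the 3 values shown sit, and the limit of > 50000 nM in this assay, at which 1 of the 3 values shown sits, are where they sit.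

Compound 4 `COc1ccc(S(=O)(=O)N(CC(N)=O)c2ccc(N(CC(N)=O)S(=O)(=O)c3ccc(NC(=O)CCN4CCC(C)CC4)cc3)c3ccccc23)cc1` is not yet measured. It differs from compound 1 in this way: (4-methylpiperidin-1-yl)methyl in place of hydrogen on a saturated chain carbon bound to a carbonyl carbon. The most similar measured step is a step that the two limits leave unreadable from compound 1 to compound 3, where the entering group is (piperidin-1-yl)methyl, and that step is unreadable. Within the data shown here, no measured step bears readably on the change; the expectation is therefore that no step beyond the scatter will show in this assay and that compound 4 will most likely again return only a limit. Compound 4 is estimated at 100000 nM, with an expected range from 50000 nM to 300000 nM. The expected step is a step that the limit leaves unreadable from compound 1 to compound 4.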

Compound 4, half-maximal cytotoxic concentration: > 100000 nM
Compound 4 gave a limit, no number; the forecaster's own chance of this, stated with the estimate: 90%; the middle value lies on the limit itself.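

In this assay compound 4 gives > 100000 nM, which is a limit and not a number. Among these compounds, none of its steps from compound 1, compound 2 or compound 3 can be read, so no new step emerges. The compounds shown leave open the actual half-maximal cytotoxic concentration of all four compounds, and whether any of these changes to the acetamido group alters it.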